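The source may report more compounds than this note shows. Statements on the series, on what has been measured and on what is new or still open speak of the compounds shown alone.

For the measured compounds named here, compound 3 `CC#CCC(C)[C@H](O)/C=C/[C@H]1[C@H](O)C[C@]2(CCCCCO)C/C(=C\CCCC(=O)O)C[C@H]12` gives 7000 nM in a functional assay for inhibition, with Homo sapiens as the target (a lower number here means a stronger inhibitor, a higher number a weaker inhibitor), the second highest of the three numbers measured so far. Compound 1 `CC#CCC(C)[C@H](O)/C=C/[C@H]1[C@H](O)C[C@]2(CCCCCO)C/C(=C/CCCC(=O)O)C[C@H]12` gives 11000 nM in this assay; the step of a 1.6-fold lower number from compound 1 to compound 3 (0.20 log units; within the scatter) is within the scatter, the two differing only in how one double bond is drawn (the fact that one of compounds 1 and 3 is drawn with a defined configuration and the other without, at the place where they differ). Compound 2 `CC#CCC(C)[C@H](O)/C=C/[C@H]1[C@H](O)C[C@]2(C#CCCCN=[N+]=[N-])C/C(=C\CCCC(=O)O)C[C@H]12` gives 20 nM in this assay, and the step of a 350-fold higher number from compound 2 to compound 3 (2.54 log units; beyond the scatter) is large. Compound 4 `CC#CCC(C)[C@H](O)/C=C/[C@H]1[C@H](O)C[C@]2(CCC#CCCCO)C/C(=C\CCCC(=O)O)C[C@H]12` is not yet measured; it differs from compound 3 by 5-hydroxypent-1-yn-1-yl in place of 3-hydroxypropyl on a saturated chain carbon, two bonds along the chain from a saturated ring carbon. Going by the values given here, of the measured steps only the one from compound 2 to compound 3 touches this side chain, and there the triple bond sits directly on a saturated ring carbon and an azide is present, so it bears on compound 4 only loosely. Compound 4 shares a triple bond in the chain with compound 2 but keeps the hydroxyl end of compound 3, so a step downward in this assay is expected, well short of the large step seen. For compound 4 the estimate is 2000 nM, with a range from 300 nM to 9000 nM. This corresponds to an expected step of a 3.5-fold lower number from compound 3 to compound 4 (0.54 log units; beyond the scatter).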

Compound 4, half-maximal inhibitory concentration: 400 nM
Beside the measured number, compound 4's estimate is 5.0-fold (0.70 log units) above it; measured number inside the range.
By their numbers in this assay, from the lowest: compound 2; then compound 4; then compounds 3 and 1 (each within the scatter of the next).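

In this assay the step of an 18-fold lower number from compound 3 to compound 4 (1.24 log units; beyond the scatter) shows that the side chain can move the number a long way while the hydroxyl end stays in place, so the azide of compound 2 is not needed for a large gain. The remaining step of a 20-fold higher number from compound 2 to compound 4 (1.30 log units; beyond the scatter) is also large, so 7-hydroxyhept-3-yn-1-yl does not match 5-azidopent-1-yn-1-yl on the saturated ring carbon. Nothing measured here bears on the cause of either step.

Going from 5-hydroxypentyl to 7-hydroxyhept-3-yn-1-yl lengthens the chain and adds a triple bond together, and the compounds shown do not separate the two. Also open, from the compounds shown here alone, is how a fully saturated 7-hydroxyheptyl chain, or an amine in place of the terminal hydroxyl, would compare.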